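A few compounds are considered here, and "the series" means these few. Any claim that something is new, unique, unknown or untested is made for them only; others in the source may bear on it.

The series is built on a shared core carrying a furanylmethylamino group, and its members are compared in a functional assay on HCT-116 cells (Homo sapiens) for cytotoxicity, read by MTT assay, with a stated time of 2 days, tested at 10 uM; on this read-out lower numbers stand for less inhibition and higher numbers for more inhibition at the one concentration tested (going by the name of the read-out). Compound 1 `c1coc(CNc2nc(NCCCN3CCCC3)nc3ccccc23)c1` gives 67.5% in this assay. Compound 2 `CCCCCNc1nc(NCc2ccco2)c2cc(F)ccc2n1`, which carries a fluorine on the core and a pentylamino group, gives 94.2% in this assay. For the measured compounds named here, compound 3 `CN(C)CCCNc1nc(NCc2ccco2)c2ccccc2n1` is reported as "not determined" (no result reported) in this assay, so it stands without a number of its own and no step from it can be stated.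

Compound 4 `CCN(CC)CCNc1nc(NCc2ccco2)c2ccccc2n1` differs from compound 3 by diethylamino in place of (dimethylamino)methyl on a saturated chain carbon, two bonds along the chain from a nitrogen on an aromatic ring. Since compound 3 has no number, the expectation for compound 4 rests on compound 1 and compound 2 alone, whose values in this assay span a considerable range, and the direction of any step cannot be foreseen beyond that.

Compound 4 is therefore expected to give about 68% in this assay, with a likely range from 40% to 92%.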

Compound 4, a percentage reported as inhibition, at one concentration (the size of the read-out at that concentration, not a potency): 50.3%
Beside the measured number, compound 4's estimate is 17.7 percentage points above it; the range from low to high includes it.
By their numbers in this assay, from the lowest: compound 4; then compound 1; then compound 2.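

In this assay, this place on the chain proves sensitive to the change: diethylamino in place of (pyrrolidin-1-yl)methyl, on a saturated chain carbon, two bonds along the chain from a nitrogen on an aromatic ring, goes with a number 17.2 percentage points lower from compound 1 to compound 4 (beyond the scatter). For the compounds shown here, this is the first step that can be read, and it shows that the ring-bearing group and the open diethylamino group are not interchangeable here. The step from compound 3 cannot be read, and nothing shown here accounts for the difference.

The compounds shown leave open how a piperidine or a morpholine in this place would compare with the pyrrolidine of compound 1. They also leave open whether a longer chain carrying the diethylamino group would change the read-out.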